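Chloro in Place of Isopropoxy: Where Compound 4 Should Land

A few compounds are considered here, and "the series" means these few. Any claim that something is new, unique, unknown or untested is made for them only; others in the source may bear on it.

Of the compounds shown here, three sharing one core have been tested in a functional assay on the whole organism (strain Sprague-Dawley) for inhibition, with Rattus norvegicus as the target; a higher number here means that more compound is needed for the effect, a lower number that less compound is needed. Compound 1 `O=c1c(-c2nn[nH]n2)c[nH]c2c(F)cccc12` gives 0.625 mg/kg. Compound 2 `CS(=O)(=O)c1cccc2c(=O)c(-c3nn[nH]n3)c[nH]c12` gives 10 mg/kg, and the step of a 16-fold higher number from compound 1 to compound 2 (1.20 log units; beyond the scatter) is large. Compound 3 `CC(C)Oc1cccc2c(=O)c(-c3nn[nH]n3)c[nH]c12` gives 0.078 mg/kg, the lowest of the three numbers; the step of an 8.0-fold lower number from compound 1 to compound 3 (0.90 log units; beyond the scatter) is modest, and the step of a 130-fold lower number from compound 2 to compound 3 (2.11 log units; beyond the scatter) is large. Compound 3 thus stands apart from both other compounds, beyond the scatter.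

Compound 4 `O=c1c(-c2nn[nH]n2)c[nH]c2c(Cl)cccc12` differs from compound 3 in one place: chloro in place of isopropoxy on an aromatic carbon. Among the measured compounds shown here, no measured step involves chloro, so the bearing steps are those that change the same aromatic carbon. The step of an 8.0-fold lower number from compound 1 to compound 3 (0.90 log units; beyond the scatter) shows that isopropoxy gave a modestly lower number than fluoro, while the step of a 16-fold higher number from compound 1 to compound 2 (1.20 log units; beyond the scatter) shows that methylsulfonyl gave a much higher number. Chloro, like fluoro, is a halogen, so compound 4 is expected to land nearer compound 1, which gave 0.625 mg/kg, than compound 3, which means an expected step of a 5.1-fold higher number from compound 3 to compound 4 (0.71 log units; beyond the scatter) in this assay. The estimate for compound 4 in this assay is 0.4 mg/kg, with a range from 0.1 mg/kg to 2 mg/kg.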

Compound 4, minimum effective dose: 0.078 mg/kg
Beside the measured number, compound 4's estimate is 5.1-fold (0.71 log units) above it; the whole stated range lies above it.
By their numbers in this assay, from the lowest: compounds 3 and 4 (each within the scatter of the next); then compound 1; then compound 2.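

In this assay, chloro and isopropoxy cannot be told apart on this aromatic carbon: the swap gives no change at the digits printed from compound 3 to compound 4 (within the scatter), so the 1 heavy atom of chloro matches the 4 heavy atoms of isopropoxy, and the low end of the series is no longer held by isopropoxy alone. The two halogens do not behave as one group here, since chloro in place of fluoro gives an 8.0-fold lower number from compound 1 to compound 4 (0.90 log units; beyond the scatter), a step of the same size as the one isopropoxy made from fluoro, while chloro in place of methylsulfonyl gives a 130-fold lower number from compound 2 to compound 4 (2.11 log units; beyond the scatter). Nothing available explains why these groups fall in this order on this carbon.

Going by these compounds, it remains open whether other groups on this carbon, such as bromo, methoxy or an amine, would fall with chloro and isopropoxy, with fluoro, or nearer methylsulfonyl. On these data alone, it is equally open whether the tie between chloro and isopropoxy would hold with a change elsewhere on the shared core.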